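A few compounds are considered here, and "the series" means these few. Any claim that something is new, unique, unknown or untested is made for them only; others in the source may bear on it.

Measured so far:
compound 1 `CC/C=C\C(=O)Nc1cc(Nc2ncc(C#N)c(-c3cn(C)c4ccccc34)n2)c(OC)cc1N(C)CCN(C)C` gives 1150 nM in a functional assay on NCI-H1975 cells (Homo sapiens) for antiproliferative activity, read by MTT assay, with a stated time of 72 h; on this read-out lower numbers stand for stronger inhibition and higher numbers for weaker inhibition
compound 2 `CCC/C=C\C(=O)Nc1cc(Nc2ncc(C#N)c(-c3cn(C)c4ccccc34)n2)c(OC)cc1N(C)CCN(C)C` gives 823 nM in this assay
compound 3 `CC/C=C\C(=O)Nc1cc(Nc2ncc(C#N)c(-c3cn(C)c4ccc(F)cc34)n2)c(OC)cc1N(C)CCN(C)C` gives 10200 nM in this assay

Compound 4 `COc1cc(N(C)CCN(C)C)c(NC(=O)/C=C\C(C)C)cc1Nc1ncc(C#N)c(-c2cn(C)c3ccc(F)cc23)n1` has not yet been measured in this assay. It differs from compound 3 by methyl in place of hydrogen on a saturated chain carbon bound to a double-bonded chain carbon and a saturated chain carbon. The same kind of change is measured once, from compound 1 to compound 2, as methyl in place of hydrogen on a saturated chain carbon, two bonds along the chain from a double-bonded chain carbon; there the methyl enters on a saturated chain carbon two bonds along the chain from a double-bonded chain carbon, whereas in compound 4 it enters on a saturated chain carbon bound to a double-bonded chain carbon and a saturated chain carbon. That measured change gave a 1.4-fold lower number from compound 1 to compound 2 (0.15 log units; within the scatter). The two cores differ by fluoro in place of hydrogen on an aromatic carbon, which gave an 8.9-fold higher number from compound 1 to compound 3 (0.95 log units; beyond the scatter), and compound 3 stands highest of the three measured numbers.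

Among the measured compounds shown here, for compound 4 the step expected in this assay is a 1.3-fold lower number from compound 3 to compound 4 (0.11 log units; within the scatter), because the only measured instance of this kind of change is a 1.4-fold lower number from compound 1 to compound 2 (0.15 log units; within the scatter), a shift that does not exceed the scatter. Compound 4 is accordingly estimated at 8000 nM, with the likely range 3000 nM to 22000 nM.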

Compound 4, half-maximal inhibitory concentration: 1130 nM
Compound 4: middle estimate off by 7.1-fold (0.85 log units), on the high side; the whole stated range lies above it.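

In this assay, methyl in place of hydrogen on the chain of the fluoro-bearing core gives a 9.0-fold lower number from compound 3 to compound 4 (0.96 log units; beyond the scatter). The size of this change does not carry from one core to the other in this series: the same change on two cores in this assay, a 1.4-fold lower number (0.15 log units; within the scatter) from compound 1 to compound 2 and a 9.0-fold lower number (0.96 log units; beyond the scatter) from compound 3 to compound 4, 6.5-fold (0.81 log units) apart, beyond the scatter of two such steps. Among the compounds shown here, this does not show that the core alone sets the size of the step: in the first pair the methyl enters on a saturated chain carbon two bonds along the chain from a double-bonded chain carbon, whereas in the second it enters on a saturated chain carbon bound to a double-bonded chain carbon and a saturated chain carbon, so core and place of entry are confounded across only one pair per core.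

The compounds shown leave open how the isopropyl end behaves on the core of compound 1, and how the straight chain of compound 2 behaves on the fluoro-bearing core. Also open, as far as these compounds go, is whether a cyclopropyl or tert-butyl group at this chain end would follow compound 4 on the fluoro-bearing core.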